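From 4-methoxybenzyl to butyl on a shared core

The compounds below may be only part of what the source reports. "The series", "measured", "known", "first", "only" and "open" are said of these compounds alone.

In a functional assay on BT-474 cells (Homo sapiens) for inhibition, read by fluorescence, with a stated time of 72 h (a lower number here means a stronger inhibitor of growth, a higher number a weaker inhibitor of growth), compound 2 `COc1ccc(Cn2cnc3c(Nc4cccc(Cl)c4)nc(N[C@H]4CC[C@H](N)CC4)nc32)cc1` gives 8200 nM. Compound 1 `CC(C)CCn1cnc2c(Nc3ccc(Cl)cc3)nc(N[C@H]3CC[C@H](N)CC3)nc21` gives 5100 nM, and compound 3 `CC(C)CCn1cnc2c(Nc3ccccc3)nc(N[C@H]3CC[C@H](N)CC3)nc21` gives 6400 nM. These three numbers lie within the usual scatter of one another, so compound 2 does not stand apart.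

Compound 4 `CCCCn1cnc2c(Nc3cccc(Cl)c3)nc(N[C@H]3CC[C@H](N)CC3)nc21` has not yet been measured. It differs from compound 2 in one group: propyl in place of 4-methoxyphenyl on a saturated chain carbon bound to an aromatic nitrogen. Cut one bond further out, the same difference reads 4-methoxybenzyl to butyl.

Among the measured compounds shown here, no measured step tests this change directly. For the measured compounds named here, the only single-place step, a 1.3-fold higher number from compound 1 to compound 3 (0.10 log units; within the scatter), concerns a different group and stays within the scatter, so it bears only loosely on this one. More useful is compound 1, which already has a chain without a ring at this place and gives 5100 nM. No step beyond the scatter is therefore expected, and the estimated change is a 1.4-fold lower number from compound 2 to compound 4 (0.14 log units; within the scatter). For compound 4, the estimate is 6000 nM, with an expected range from 2500 nM to 14000 nM.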

Compound 4, concentration for 50% growth inhibition: 5100 nM
Compound 4: middle estimate off by 1.2-fold (0.07 log units), on the high side; the range from low to high includes it.
By their numbers in this assay, from the lowest: compounds 1, 4, 3 and 2 (each within the scatter of the next).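

Among the compounds shown here, this is the only measured step that changes the group on a saturated chain carbon bound to an aromatic nitrogen while the rest of the molecule stays the same. In this assay, going from 4-methoxybenzyl to butyl gives a small step (a 1.6-fold lower number from compound 2 to compound 4 (0.21 log units; within the scatter)), so removing the six-membered aromatic ring and its methoxy group does not move the number beyond the scatter. Nothing in the data offers an explanation for how the two compounds compare.

On these data alone, whether a plain benzyl group, or a chain ending in an amine or a carboxylic acid, would move the number beyond the scatter remains open. So does whether the same change from 4-methoxybenzyl to butyl would read alike on a core without the chloro group.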